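This account rests on a few compounds, and the source may have more. Where it says the series, first, only, none or still open, it means among the compounds named here.

Of the compounds shown here, three that share one core have been measured in a physicochemical assay for lipophilicity, in phosphate buffer, measured as octanol-water partition, with a stated time of 24 h; on this read-out higher numbers stand for higher lipophilicity and lower numbers for lower lipophilicity. Compound 1, `O=C(CSc1nc2ccccc2s1)N/N=C/c1ccc(Oc2ccc(Br)cc2)cc1`, gives 5.7. Compound 2, `O=C(CSc1nc2ccccc2s1)N/N=C/c1ccc(Oc2ccc([N+](=O)[O-])cc2)cc1`, gives 5.3. Compound 3, `Cc1ccc(Oc2ccc(/C=N/NC(=O)CSc3nc4ccccc4s3)cc2)cc1`, gives 5.7. On these numbers compound 3 stands level with compound 1 at the top of the three, while compound 2 sits below both: a number 0.40 log units higher from compound 2 to compound 3 (beyond the scatter). Each measured step swaps one group for another on an aromatic carbon: a number 0.40 log units lower from compound 1 to compound 2 (beyond the scatter), whereas no change at the digits printed from compound 1 to compound 3 (within the scatter).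

Compound 4, `Cc1cc(Oc2ccc(/C=N/NC(=O)CSc3nc4ccccc4s3)cc2)ccc1Cl`, has not yet been measured. It differs from compound 3 in one place: 4-chloro-3-methylphenyl in place of 4-methylphenyl on an oxygen on an aromatic ring. Among the compounds with values here, none of the measured steps adds a chlorine to a ring that keeps its methyl, so no step bears on this change directly. The closest comparison is the exchange of bromo for methyl, which stayed within the scatter, and the exchange of bromo for nitro, which gave a modest drop; taken together they suggest that a single halogen on that ring moves the number little. A rise of no more than modest size is therefore expected in this assay for compound 4, a number 0.40 log units higher from compound 3 to compound 4 (beyond the scatter). Compound 4 is estimated at 6.1, with a range from 5.7 to 6.5.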

Compound 4, partition coefficient: 5.7
Beside the measured number, compound 4's estimate is 0.40 log units above it, within the range that was stated.
By their numbers in this assay, from the lowest: compound 2; then compounds 1, 3 and 4 (each within the scatter of the next).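

In this assay, the group on the oxygen on an aromatic ring can grow from 4-methylphenyl to 4-chloro-3-methylphenyl and the read-out holds, with no change at the digits printed from compound 3 to compound 4 (within the scatter) for this larger group. The new group also matches 4-bromophenyl, with no change at the digits printed from compound 1 to compound 4 (within the scatter), while the one gap that stands out is to 4-nitrophenyl, with a number 0.40 log units higher from compound 2 to compound 4 (beyond the scatter), so among these four compounds only compound 2 stands apart from the others beyond the scatter. Nothing available explains why the extra atom leaves the number where it was.

The compounds shown leave open how a ring carrying only the chlorine or only a methyl at the new place would read, since the two features of 4-chloro-3-methylphenyl are seen here only together. They also leave open whether an amine, a carboxylic acid or a longer chain such as butyl on this same ring would move the number further from the level shared by compound 1, compound 3 and compound 4 than the nitro group of compound 2 does.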